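The source may hold more compounds than are shown below. What is called first, only, known or untested is meant among the compounds shown, and "the series" means these compounds.

Compound 1 `Nc1ccccc1NC(=O)c1ccc(CSC(=S)N2CCN(Cc3ccncc3)CC2)cc1`: 89.5% in a functional assay on A-375 cells (Homo sapiens) for antiproliferative activity, read by CCK-8 assay, with a stated time of 72 h, tested at 8 uM; a lower number here means a weaker effect, a higher number a stronger effect of the compound at the concentration tested
Compound 2 `Nc1ccccc1NC(=O)c1ccc(CSC(=S)N2CCN(C(c3ccccc3)c3ccccc3)CC2)cc1`: 8.4% in this assay

Of the two compounds measured in this assay, compound 1 gives the higher number, and compound 2 lies far beneath it, beyond the scatter. Compound 3 `Nc1ccccc1NC(=O)c1ccc(CSC(=S)N2CCN(c3cnccn3)CC2)cc1` has not been measured. It differs from compound 1 in one place: pyrazin-2-yl in place of (pyridin-4-yl)methyl on an amine nitrogen in a ring. Going by the values given here, no step between measured compounds covers this change, so the expectation rests on compound 1 alone. The step from compound 1 to compound 3 is expected to be a number 29.5 percentage points lower from compound 1 to compound 3 (beyond the scatter), a fall beyond the scatter but well short of the gap to compound 2. For compound 3 the estimated read-out is 60%, with a range from 20% to 90%.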

Compound 3, a percentage reported as inhibition, at one concentration (the size of the read-out at that concentration, not a potency): 85.8%
For compound 3 the middle estimate is 25.8 percentage points below the measured one; low and high end bracket the measured number.
By their numbers in this assay, from the lowest: compound 2; then compounds 3 and 1 (each within the scatter of the next).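

In this assay, pyrazin-2-yl in place of (pyridin-4-yl)methyl on the amine nitrogen in the ring gives a number 3.7 percentage points lower from compound 1 to compound 3 (within the scatter). The high read-out of compound 1 therefore does not depend on the (pyridin-4-yl)methyl group: a different aromatic ring with 2 hetero atoms, set directly on this nitrogen, serves as well at the concentration tested. Nothing at hand explains this result. On these data alone, it remains open whether a plain phenyl ring or an acetyl group on this nitrogen would keep the read-out. A single concentration also leaves any difference in potency between compound 1 and compound 3 unresolved.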